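Chain extension in chloroalkanamide series: HT-29 antiproliferation notes

A few compounds are considered here, and "the series" means these few. Any claim that something is new, unique, unknown or untested is made for them only; others in the source may bear on it.

Compound 1 `CC(C)(C)c1ccc(NC(=O)CCl)cc1` gives 15000 nM in a functional assay on HT-29 cells (Homo sapiens) for antiproliferative activity, with a stated time of 48 h; on this read-out higher numbers stand for weaker inhibition and lower numbers for stronger inhibition. Compound 2 `CC(C)(C)c1ccc(NC(=O)CCCl)cc1` carries chloromethyl in place of chloro on a saturated chain carbon bound to a carbonyl carbon and gives 88000 nM; the step is a 5.9-fold higher number from compound 1 to compound 2 (0.77 log units; beyond the scatter). Compound 3 `CC(C)(C)c1ccc(CNC(=O)CCCl)cc1` gives 87000 nM, a value within the scatter of compound 2. The difference between the core of compound 1 and the core of compound 3 is not broken down here.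

Compound 4 `CC(C)(C)c1ccc(CNC(=O)CCCCl)cc1` is not yet measured; relative to compound 3 it carries chloromethyl in place of chloro on a saturated chain carbon, two bonds along the chain from a carbonyl carbon. This is the same kind of change as that from compound 1 to compound 2, but the place is not identical: there it sits on a saturated chain carbon bound to a carbonyl carbon, here on a saturated chain carbon, two bonds along the chain from a carbonyl carbon. Within the data shown here, the one measured step of this kind, a 5.9-fold higher number from compound 1 to compound 2 (0.77 log units; beyond the scatter), raised the number beyond the scatter, and compound 3 already stands at 87000 nM. Compound 4 is therefore expected to weaken further, a 2.3-fold higher number from compound 3 to compound 4 (0.36 log units; beyond the scatter), with a fair chance that this assay reports only a limit. The estimate for compound 4 is 200000 nM, between 80000 nM and 600000 nM.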

Compound 4, half-maximal inhibitory concentration: 72000 nM
Beside the measured number, compound 4's estimate is 2.8-fold (0.44 log units) above it, and the stated range ends above it.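

On the second core, the change gives a 1.2-fold lower number from compound 3 to compound 4 (0.08 log units; within the scatter), so the rise in the number seen on the first core does not recur in this assay. Set side by side, the two steps differ, and a step measured on one core cannot be taken as a forecast for the other in this series: the same change on two cores in this assay, a 5.9-fold higher number (0.77 log units; beyond the scatter) from compound 1 to compound 2 and a 1.2-fold lower number (0.08 log units; within the scatter) from compound 3 to compound 4, 7.1-fold (0.85 log units) apart, beyond the scatter of two such steps

This does not show what separates the two results, since the cores differ and the change also sits at a different place on the chain: on a saturated chain carbon bound to a carbonyl carbon in one case, and two bonds along the chain from a carbonyl carbon in the other. With one step on each core, it also gives no general rule for either core.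

The compounds shown leave open how a longer chain than 3-chloropropyl would read out on either core. They also leave open whether a bromo or an amine in place of the chloro would keep the number in the same range.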